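Swapping Bromo for Trifluoromethyl in Compound 3

A few compounds are considered here, and "the series" means these few. Any claim that something is new, unique, unknown or untested is made for them only; others in the source may bear on it.

Measured in a functional assay on WM 266-4 cells (Homo sapiens) for antiproliferative activity, read by MTT assay, with a stated time of 48 h; a lower number here means a stronger inhibitor, a higher number a weaker inhibitor:
compound 1 `Fc1ccc(C2=NN(c3nc(-c4ccc(C(F)(F)F)cc4)cs3)C(c3cccs3)C2)cc1`: 5120 nM
compound 2 `Cc1ccc(C2=NN(c3nc(-c4ccc(C(F)(F)F)cc4)cs3)C(c3cccs3)C2)cc1`: 2110 nM
compound 3 `Brc1ccc(C2=NN(c3nc(-c4ccc(Br)cc4)cs3)C(c3cccs3)C2)cc1`: 13000 nM

Compound 3 stands highest of the three; compound 1 is its nearest, compound 2 its furthest, both lower beyond the scatter. Compound 4 `FC(F)(F)c1ccc(-c2csc(N3N=C(c4ccc(Br)cc4)CC3c3cccs3)n2)cc1` differs from compound 3 in one place: trifluoromethyl in place of bromo on an aromatic carbon. Among the compounds with values here, the single measured step, a 2.4-fold lower number from compound 1 to compound 2 (0.38 log units; beyond the scatter), sits on the other aromatic ring and does not bear on this change; no measured pair isolates bromo against trifluoromethyl. Compounds 1 and 2, which carry trifluoromethyl at this place, both give lower numbers than compound 3, yet they differ elsewhere too, so the expected step, a 2.2-fold lower number from compound 3 to compound 4 (0.34 log units; beyond the scatter), is a modest lowering held with little confidence. Compound 4 is estimated at 6000 nM, within 2500 nM to 15000 nM.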

Compound 4, half-maximal inhibitory concentration: 27400 nM
Compound 4: middle estimate off by 4.6-fold (0.66 log units), on the low side, and the stated range ends below it.
By their numbers in this assay, from the lowest: compound 2; then compound 1; then compound 3; then compound 4.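

Trifluoromethyl in place of bromo gives a 2.1-fold higher number from compound 3 to compound 4 (0.32 log units; beyond the scatter) and so raises the number, a direction the earlier compounds could not show, since no pair isolated this change. With trifluoromethyl held at this place, the substituent on the other aromatic ring also counts: bromo in place of methyl gives a 13-fold higher number from compound 2 to compound 4 (1.11 log units; beyond the scatter) and bromo in place of fluoro gives a 5.4-fold higher number from compound 1 to compound 4 (0.73 log units; beyond the scatter), the larger and smaller of these two steps. Nothing measured here accounts for these steps. Going by these compounds, whether the bromo-to-trifluoromethyl step runs the same way with methyl or fluoro on the other ring remains open, as does how an amine or a carboxylic acid would fare at this place.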